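A few compounds are considered here, and "the series" means these few. Any claim that something is new, unique, unknown or untested is made for them only; others in the source may bear on it.

Of the compounds shown here, two of a shared core have been tested in an assay for displacement of a labelled ligand from Sigma non-opioid intracellular receptor 1 (Cavia porcellus), read by scintillation counting, with a stated time of 180 min; a higher number here means a weaker inhibitor, a lower number a stronger inhibitor. Compound 1 `COC1Cc2c(cnn2-c2ccccc2)C2(CCN(Cc3ccco3)CC2)O1` gives 2.2 nM in this assay. Compound 2 `COC1Cc2c(cnn2-c2ccccc2)C2(CCN(C(C)C)CC2)O1` gives 210 nM in this assay, the higher of the two numbers, so compound 2 is the weaker inhibitor of this pair. For the measured compounds named here, the only step so far is a 95-fold higher number from compound 1 to compound 2 (1.98 log units; beyond the scatter), which shows that the group on the ring amine nitrogen matters a great deal here. Compound 3 `CCCCN1CCC2(CC1)OC(OC)Cc1c2cnn1-c1ccccc1` is not yet measured. It differs from compound 2 in one place: butyl in place of isopropyl on an amine nitrogen in a ring. Going by the values given here, no measured step swaps one short alkyl chain for another, so the earlier step gives only loose guidance. Compound 3 is therefore expected to sit close to compound 2, with a step of a 1.4-fold lower number from compound 2 to compound 3 (0.15 log units; within the scatter) that stays within the usual scatter. The estimate for compound 3 in this assay is 150 nM, with a range from 50 nM to 450 nM.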

Compound 3, inhibition constant: 8 nM
Compound 3: the middle estimate sits 19-fold (1.27 log units) above what was measured; the whole stated range lies above it.
By their numbers in this assay, from the lowest: compound 1; then compound 3; then compound 2.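

Swapping in butyl for isopropyl on the amine nitrogen in a ring gives a 26-fold lower number from compound 2 to compound 3 (1.42 log units; beyond the scatter), so in this assay the choice between two plain carbon groups can matter about as much at this position as the loss of the (furan-2-yl)methyl group did. A furan ring is not needed for a low number here, although compound 1 keeps an edge: a 3.6-fold higher number from compound 1 to compound 3 (0.56 log units; beyond the scatter) is a modest step, much smaller than a 95-fold higher number from compound 1 to compound 2 (1.98 log units; beyond the scatter). Nothing available explains why butyl and isopropyl differ so sharply on this nitrogen.

From the compounds shown here alone, it remains open whether the gain comes from chain length or from the lack of branching, which a straight propyl group or a longer chain such as hexyl could help to separate. Going by these compounds, it is also open how a benzyl group would compare with the (furan-2-yl)methyl group.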